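The source may hold more compounds than are shown below. What is called first, only, known or untested is meant among the compounds shown, and "the series" means these compounds.

Measured compounds:
compound 1 `CC[C@H](C)[C@H](NC(=O)c1cccc(Cn2ccnc2)c1)C(=O)NNS(=O)(=O)c1ccccc1` — 6%
compound 2 `CCCCS(=O)(=O)NNC(=O)[C@@H](NC(=O)c1cccc(Cn2ccnc2)c1)[C@@H](C)CC` — "not determined" (no result reported)
compound 3 `CCCCCS(=O)(=O)NNC(=O)[C@@H](NC(=O)c1cccc(Cn2ccnc2)c1)[C@@H](C)CC` — "not determined" (no result reported)

Among the compounds with values here, in an assay on HEK293 cells for displacement of a labelled ligand from Type-2 angiotensin II receptor (Homo sapiens), tested at 1 uM (on this read-out lower numbers stand for a weaker effect and higher numbers for a stronger effect at the one concentration tested), compound 1 gives 6%, the only number in this set; compound 2 and compound 3 carry no result, so compound 1 stands alone and its read-out is small. Compound 4 `CC[C@H](C)[C@H](NC(=O)c1cccc(Cn2ccnc2)c1)C(N)=O` is the next one to be measured there. It differs from compound 1 in one place: hydrogen in place of (phenylsulfonyl)amino on an amide-type nitrogen. Within the data shown here, no step between measured compounds is available to gauge such a change. Since compound 1 already sits low at 6%, the step from compound 1 to compound 4 is expected to be none beyond the scatter, a number 1 percentage points lower from compound 1 to compound 4 (within the scatter). Compound 4 is therefore estimated at 5%, with a range from -5% to 20%.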

Compound 4, a percentage reported as inhibition, at one concentration (the size of the read-out at that concentration, not a potency): "not active" (no number reported)
The entry for compound 4 holds no number; there is nothing to compare the estimate with.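

In this assay compound 1 gives 6% and compound 4 is reported as not active without a number, so no step can be read between them. No available evidence bears on this result. The compounds shown leave open whether losing the (phenylsulfonyl)amino group changes the read-out at all.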